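A few compounds are considered here, and "the series" means these few. Any claim that something is new, unique, unknown or untested is made for them only; others in the source may bear on it.

In a toxicity assay on HepG2 cells (Homo sapiens) for inhibition, read by CellTiter-Glo, with a stated time of 48 h (a lower number here means a stronger inhibitor, a higher number a weaker inhibitor), compound 1 `CCOc1ccc2nc(C(F)(F)F)cc(OCC(=O)Nc3cc(C)cc(C)c3)c2c1` is reported only as a limit, > 100000 nM. Compound 2 `COc1ccc2nc(C)c(NC(=O)C(=O)Nc3cc(C)cc(C)c3)c(O)c2c1` likewise returns a limit in this assay, > 100000 nM. Among the compounds with values here, compound 3 `COc1ccc2nc(C)cc(OCC(=O)Nc3ccc(Br)c(C)c3)c2c1` is the one member of the series with a number in this assay, 15900 nM. The remaining values are the limit of > 100000 nM in this assay, at which 2 of the 3 values shown sit. Compound 4 `COc1ccc2nc(C)cc(OCC(=O)Nc3ccncn3)c2c1` has not yet been measured in this assay. Compound 4 differs from compound 3 by pyrimidin-4-yl in place of 4-bromo-3-methylphenyl on an amide-type nitrogen. Within the data shown here, no measured pair carries this change, so no step size is known from the data. The change is expected to make compound 4 a weaker inhibitor than compound 3 by more than the scatter, the estimated step from compound 3 to compound 4 being a 3.8-fold higher number from compound 3 to compound 4 (0.58 log units; beyond the scatter). Compound 4 is expected near 60000 nM, within 15000 nM to 200000 nM, with a fair chance that only a limit is reported.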

Compound 4, half-maximal inhibitory concentration: > 100000 nM
Compound 4 gave a limit, no number (the forecaster's own chance of this, stated with the estimate: 55%); middle value at least 1.6-fold (0.22 log units) from the limit.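

Pyrimidin-4-yl in place of 4-bromo-3-methylphenyl on an amide-type nitrogen gives the first single-place step in this series in this assay, an at least 6.2-fold higher number from compound 3 to compound 4 (0.79 log units; beyond the scatter). The value of compound 4 is a limit, so this step gives a bound and not a size. Compound 3 remains the only compound with a number: the limit of > 100000 nM in this assay, at which 3 of the 4 values shown sit.

The compounds shown do not separate the roles of the bromine, the methyl and the all-carbon ring in this step. Going by these compounds, how a plain phenyl or a cyclohexyl on that nitrogen would read remains open.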